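Ring amide variation on the shared core: cytotoxicity limits

A few compounds are considered here, and "the series" means these few. Any claim that something is new, unique, unknown or untested is made for them only; others in the source may bear on it.

Compound 1, `CC(C)C(=O)N1C[C@H](NC(=O)c2ccc(-n3ccccc3=O)cc2)[C@H](NC(=O)c2ccc(Cl)s2)C1`, sits at the assay limit in an ADME assay on HEK293 cells (Homo sapiens) for cytotoxicity (on this read-out higher numbers stand for weaker inhibition and lower numbers for stronger inhibition), giving > 100000 nM.
Compound 2, `O=C(N[C@H]1CN(C(=O)C2CC2)C[C@H]1NC(=O)c1ccc(Cl)s1)c1ccc(-n2ccccc2=O)cc1`, also reaches only the limit of this assay, giving > 100000 nM.
Compound 3, `O=C(N[C@H]1CN(C(=O)N2CCCC2)C[C@H]1NC(=O)c1ccc(Cl)s1)c1ccc(-n2ccccc2=O)cc1`, likewise stops at the limit of this assay, giving > 100000 nM.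

Compound 1 is therefore known only as a limit in this assay, and the same holds for the two other values shown, as the limit of > 100000 nM in this assay, at which 3 of the 3 values shown sit, records. The steps that replace the isopropyl on the carbonyl carbon are all unreadable on this footing: a step that the two limits leave unreadable from compound 1 to compound 2, a step that the two limits leave unreadable from compound 1 to compound 3 and a step that the two limits leave unreadable from compound 2 to compound 3 give no size and no direction, since each end sits at the limit.

Compound 4, `CN(C)C(=O)N1C[C@H](NC(=O)c2ccc(-n3ccccc3=O)cc2)[C@H](NC(=O)c2ccc(Cl)s2)C1`, differs from compound 1 by dimethylamino in place of isopropyl on a carbonyl carbon. The three measured steps bear on it in that each also swaps the group on that carbonyl carbon, and none of them moved any compound off the limit. No step beyond the scatter is therefore expected in this assay, and compound 4 is expected to remain at the limit, with a number no higher from compound 1 to compound 4 (the limit leaves the size open) as the estimated step. For compound 4 the estimate in this assay is 100000 nM, within 50000 nM to 200000 nM.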

Compound 4, half-maximal inhibitory concentration: > 100000 nM
Compound 4: no number, only a limit; the forecaster's own chance of this, stated with the estimate: 90%; the middle value lies on the limit itself.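

Compound 4 also stops at a limit, so its steps to compound 1, compound 2 and compound 3 cannot be read in this assay, and no new step emerges: the limit of > 100000 nM in this assay, at which 4 of the 4 values shown sit.

The compounds shown leave open whether swapping the group on this carbonyl carbon changes the read-out at all, and how these compounds would rank beyond the limit.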